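A few compounds are considered here, and "the series" means these few. Any claim that something is new, unique, unknown or untested is made for them only; others in the source may bear on it.

Measured compounds:
compound 1 `Cc1cccc(S(=O)(=O)N[C@H]2C3CC[C@H](C3)[C@@H]2C/C=C\CCCC(=O)O)c1`, 1700 nM in a functional assay (plasma) for inhibition, with Oryctolagus cuniculus as the target; a higher number here means a weaker inhibitor, a lower number a stronger inhibitor
compound 2 `O=C(O)CCC/C=C\C[C@H]1[C@@H]2CCC(C2)[C@@H]1NS(=O)(=O)c1ccc(C(=O)O)cc1`, 800000 nM in this assay
compound 3 `O=C(O)CCC/C=C\C[C@H]1[C@@H]2CCC(C2)[C@@H]1NC(=O)c1ccccc1`, a limit of this assay, > 800000 nM

Compound 2 gives the highest number of the two measured values in this assay. The value of compound 3 is only a limit (the limit of > 800000 nM in this assay, at which 1 of the 3 values shown sits). Compound 4 `COc1ccc(S(=O)(=O)N[C@H]2C3CC[C@H](C3)[C@@H]2C/C=C\CCCC(=O)O)cc1` differs from compound 2 by methoxy in place of carboxy on an aromatic carbon. Going by the values given here, the one measured step that bears on this change is a 470-fold higher number from compound 1 to compound 2 (2.67 log units; beyond the scatter), where the carboxy entered together with a shift of the ring substituent; taking it away again is expected to undo most of that rise. The step from compound 2 to compound 4 is therefore expected to be a large fall, a 270-fold lower number from compound 2 to compound 4 (2.43 log units; beyond the scatter). Compound 4 is estimated at 3000 nM, between 800 nM and 15000 nM.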

Compound 4, half-maximal inhibitory concentration: 1700 nM
Compound 4: the middle estimate sits 1.8-fold (0.25 log units) above what was measured, and the stated range covers the measured number.
By their numbers in this assay, from the lowest: compounds 1 and 4 (each within the scatter of the next); then compound 2.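

In this assay, the change from carboxy to methoxy on the same aromatic carbon gives a 470-fold lower number from compound 2 to compound 4 (2.67 log units; beyond the scatter), so the large loss in compound 2 appears at this position without any shift of the ring substituent. Between the two neutral aryl groups, 4-methoxyphenyl and 3-methylphenyl, the data show no change at the digits printed from compound 1 to compound 4 (within the scatter). Nothing shown gives a reason for the effect of the carboxy. On these data alone, it remains open whether an amine, a hydroxyl or a chlorine atom on this carbon would behave like methoxy or like carboxy.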